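The compounds below may be only part of what the source reports. "The series", "measured", "known", "first", "only" and "open" are said of these compounds alone.

Compound 1, `Cc1ccc2[nH]c(C(=O)N[C@H]3CN(S(=O)(=O)c4ccccc4)C[C@@H]3C(=O)N[C@H]3CCCN(C)C3)cc2c1`, gives 0.3 10^-6 cm/s in an ADME assay on Caco-2 cells (Homo sapiens) for permeability, in the apical to basolateral direction, at pH 7.4; a higher number here means that the compound crosses the layer faster, a lower number that the compound crosses the layer more slowly.
Compound 2, `Cc1ccc2[nH]c(C(=O)N[C@H]3CN(S(=O)(=O)c4ccccc4)C[C@@H]3C(=O)N[C@H]3CCCNC3)cc2c1`, gives 0.04 10^-6 cm/s in this assay.
Compound 3, `Cc1ccc2[nH]c(C(=O)N[C@H]3CCN(S(=O)(=O)c4ccccc4Cl)C[C@@H]3C(=O)N[C@H]3CCCN(C)C3)cc2c1`, gives 0.27 10^-6 cm/s in this assay.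

Compound 2 differs from compound 1 in one place only: hydrogen in place of methyl on an amine nitrogen in a ring. In this assay that change brought a 7.5-fold lower number from compound 1 to compound 2 (0.88 log units; beyond the scatter). Compound 3 carries a different core from compound 1; the difference between the two cores is not broken down here. In this assay the values of compound 3 and compound 1 lie within the scatter of each other, so the two cores cannot be told apart on this read-out.

Compound 4, `Cc1ccc2[nH]c(C(=O)N[C@H]3CCN(S(=O)(=O)c4ccccc4Cl)C[C@@H]3C(=O)N[C@H]3CCCNC3)cc2c1`, has not yet been measured. It stands to compound 3 as compound 2 stands to compound 1: hydrogen in place of methyl on an amine nitrogen in a ring. The place of the change is the same word for word in both pairs, so this is the same change made on the other core. For the measured compounds named here, since the two cores gave numbers within the scatter of each other, the earlier step is the only guide, and it was beyond the scatter. Compound 4 is therefore expected to show a step of a 6.8-fold lower number from compound 3 to compound 4 (0.83 log units; beyond the scatter) in this assay, because the same change gave a 7.5-fold lower number from compound 1 to compound 2 (0.88 log units; beyond the scatter). On that basis compound 4 is estimated at 0.04 10^-6 cm/s, most likely between 0.015 10^-6 cm/s and 0.1 10^-6 cm/s.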

Compound 4, apparent permeability in the Caco-2 assay: < 0.01 10^-6 cm/s
Compound 4: no number, only a limit; the forecaster's own chance of this, stated with the estimate: 15%; at least 4.0-fold (0.60 log units) between middle value and limit.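

In the Caco-2 assay the change from methyl to hydrogen on the ring amine nitrogen carried over to the second core in direction, with an at least 27-fold lower number from compound 3 to compound 4 (1.43 log units; beyond the scatter), but it did not carry over in size: the same change on two cores in the Caco-2 assay, a 7.5-fold lower number (0.88 log units; beyond the scatter) from compound 1 to compound 2 and an at least 27-fold lower number (1.43 log units; beyond the scatter) from compound 3 to compound 4, at least 3.6-fold (0.55 log units) apart, beyond the scatter of two such steps. The reading for compound 4, < 0.01 10^-6 cm/s, is a limit of the assay and not a number, so the step on this core has a lower bound but no known full size: the limit of < 0.01 10^-6 cm/s in the Caco-2 assay, at which 1 of the 4 values shown sits. For the compounds shown here, the result does not show why the step is larger on this core, and the only further measurement on this pair is in a physicochemical assay for lipophilicity, measured as octanol-water partition, at pH 7.4 (on this read-out higher numbers stand for higher lipophilicity and lower numbers for lower lipophilicity), where compound 3 gives 3.1 and compound 4 gives 1.9, which on its own cannot settle the cause: the measured distribution coefficient of compound 3, 3.1, and of compound 4, 1.9, a number 1.20 log units lower (beyond the scatter).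

The compounds shown leave open how the Caco-2 assay responds to other groups on the same amine nitrogen, such as an ethyl group, an acetyl group or a longer chain, as only methyl and hydrogen stand there. They also leave open whether the larger step on the core of compound 3 would recur on any further core, as this change is seen on two cores only.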